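Substituted aryl hydrazones on a shared urea core

The source may hold more compounds than are shown below. What is called first, only, known or untested is meant among the compounds shown, and "the series" means these compounds.

Three compounds were measured in a functional assay on NCI-H460 cells (Homo sapiens) for cytotoxicity, read by MTT assay, with a stated time of 72 h; a higher number here means a weaker inhibitor, a lower number a stronger inhibitor:
compound 1 `COc1ccc(OC)c(/C=N/NC(=O)Nc2ccc(Oc3ccnc(-c4nncn4CCN(C)C)c3)c(F)c2)c1` gives 2930 nM;
compound 2 `CN(C)CCn1cnnc1-c1cc(Oc2ccc(NC(=O)N/N=C/c3cccc(Cl)c3Cl)cc2F)ccn1` gives 72 nM;
compound 3 `CN(C)CCn1cnnc1-c1cc(Oc2ccc(NC(=O)N/N=C/c3cc(C(C)(C)C)cc(C(C)(C)C)c3O)cc2F)ccn1` gives 590 nM.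

Compound 2 stands lowest of the three, below compound 3 and far below compound 1. Compound 4 `CN(C)CCn1cnnc1-c1cc(Oc2ccc(NC(=O)N/N=C/c3ccc(O)c(Br)c3)cc2F)ccn1` differs from compound 2 at the carbon with a double bond to nitrogen: 3-bromo-4-hydroxyphenyl in place of 2,3-dichlorophenyl on a carbon with a double bond to nitrogen. Within the data shown here, the one step that bears on this place is a 41-fold lower number from compound 1 to compound 2 (1.61 log units; beyond the scatter), which shows that the aryl group here can move the number greatly. Among the measured compounds shown here, no measured pair shows a 3-bromo-4-hydroxyphenyl, so the direction is uncertain; compound 3, whose aryl group also bears a hydroxyl, gives a higher number than compound 2. A moderate upward step is therefore expected in this assay, a 4.2-fold higher number from compound 2 to compound 4 (0.62 log units; beyond the scatter). Compound 4 is estimated at 300 nM, within 80 nM to 1200 nM.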

Compound 4, half-maximal inhibitory concentration: 430 nM
The estimate for compound 4 lay 1.4-fold (0.16 log units) below the measured number; measured number inside the range.
By their numbers in this assay, from the lowest: compound 2; then compounds 4 and 3 (each within the scatter of the next); then compound 1.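

In this assay, a 3-bromo-4-hydroxyphenyl group on this carbon gives a 6.0-fold higher number from compound 2 to compound 4 (0.78 log units; beyond the scatter), while the same change from the other side gives a 6.8-fold lower number from compound 1 to compound 4 (0.83 log units; beyond the scatter). The position therefore tolerates a group with a hydrogen-bond donor and still separates compound 4 clearly from both compound 1 and compound 2. No measurement is available that explains either step. The compounds shown leave open how much of these steps belongs to the bromine and how much to the hydroxyl. They also leave open what an aryl group bearing an amine or a carboxylic acid would give on this carbon.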